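Trimming the Terminal Amine on a Shared Core

The compounds below may be only part of what the source reports. "The series", "measured", "known", "first", "only" and "open" are said of these compounds alone.

Three compounds with the same core differ only at the far end of a saturated chain. Compound 1 `C[C@@H](CCCN1CCN(C)CC1)Nc1ccnc2cc(Cl)ccc12` gives 140000 nM in an assay for binding affinity, read by spectrophotometry; on this read-out lower numbers stand for stronger inhibition and higher numbers for weaker inhibition. Compound 2 `C[C@H](CCCN1CCN(C)CC1)Nc1ccnc2cc(Cl)ccc12` gives 180000 nM in this assay; the step of a 1.3-fold higher number from compound 1 to compound 2 (0.11 log units; within the scatter) rests on (the fact that compounds 1 and 2 differ only in the configuration as drawn). Compound 3 `C[C@@H](CCCN1CCCCC1)Nc1ccnc2cc(Cl)ccc12` gives 150000 nM in this assay, and the step of a 1.1-fold higher number from compound 1 to compound 3 (0.03 log units; within the scatter) shows that exchanging the chain-end amine left the number where it was. Compound 2 carries the highest of the three numbers, yet both other compounds sit within the scatter of it, so no ordering can be read.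

Compound 4 `C[C@H](CCCN(C)C)Nc1ccnc2cc(Cl)ccc12` is not yet measured. Its change from compound 2 is dimethylamino in place of 4-methylpiperazin-1-yl on a saturated chain carbon, four bonds along the chain from a nitrogen on an aromatic ring. The step from compound 1 to compound 3 is the one that bears on it, since it also replaced 4-methylpiperazin-1-yl at the same place, and it stayed within the scatter. The expected step of a 1.1-fold lower number from compound 2 to compound 4 (0.05 log units; within the scatter) is therefore none beyond the scatter. For compound 4 the estimate in this assay is 160000 nM, with a range from 70000 nM to 360000 nM.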

Compound 4, half-maximal inhibitory concentration: 190000 nM
The estimate for compound 4 lay 1.2-fold (0.07 log units) below the measured number; measured number inside the range.
By their numbers in this assay, from the lowest: compounds 1, 3, 2 and 4 (each within the scatter of the next).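

With a 1.1-fold higher number from compound 2 to compound 4 (0.02 log units; within the scatter) in this assay, the exchange at this place now holds for a second change of a different kind. Compound 3 kept a six-membered ring at the chain end, whereas compound 4 carries dimethylamino, which has no ring and 3 heavy atoms in place of the 7 of 4-methylpiperazin-1-yl, and still no change can be read. No measured fact shown here bears on this result.

The compounds shown leave open whether a chain end without any amine, such as a hydroxyl or a carboxylic acid, or a longer chain carrying the same dimethylamino, would give a step beyond the scatter. They also leave open whether the drawn configuration matters with dimethylamino at the chain end.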